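The source may hold more compounds than are shown below. What is called first, only, known or untested is meant among the compounds shown, and "the series" means these compounds.

Measured compounds in a functional assay on MDA-MB-231 cells (Homo sapiens) for inhibition, read by MTT assay, with a stated time of 72 h, tested at 20 uM; on this read-out lower numbers stand for less inhibition and higher numbers for more inhibition at the one concentration tested (going by the name of the read-out):
compound 1 `c1ccc(CNc2ccc(Oc3ncnc4ccsc34)cc2)cc1`, 3.72%
compound 2 `CN(c1ccc(Oc2ncnc3sccc23)cc1)c1nccc(N2CCc3ccccc3C2)n1`, 24.3%
compound 3 `CN(c1ccc(Oc2ncnc3ccsc23)cc1)c1nccc(N2CCc3ccccc3C2)n1`, 30.2%

Compound 3 gives the highest of the three numbers; its gap to compound 2 is within the scatter, while compound 1 lies beyond the scatter below it. Among the measured compounds shown here, the only measured step, a number 5.9 percentage points higher from compound 2 to compound 3 (within the scatter), exchanges the ring pair on the aryl oxygen and does not touch the amine substituent, so it has no direct bearing on the next change. Compound 4 `CN(c1ccc(Oc2ncnc3ccsc23)cc1)c1nccc(N2CCCCC2)n1` differs from compound 3 by piperidin-1-yl in place of 1,2,3,4-tetrahydroisoquinolin-2-yl on an aromatic carbon. For the measured compounds named here, both compounds 2 and 3 carry the 1,2,3,4-tetrahydroisoquinolin-2-yl group, so no measured step tests this replacement. The expected step is a number 8.2 percentage points lower from compound 3 to compound 4 (within the scatter), an estimate that stays within the scatter. Compound 4 is estimated at 22%, within 5% to 40%.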

Compound 4, a percentage reported as inhibition, at one concentration (the size of the read-out at that concentration, not a potency): 49.7%
Beside the measured number, compound 4's estimate is 27.7 percentage points below it, outside the stated range (above it).
By their numbers in this assay, from the lowest: compound 1; then compounds 2 and 3 (each within the scatter of the next); then compound 4.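

With piperidin-1-yl in place of 1,2,3,4-tetrahydroisoquinolin-2-yl, this assay shows a number 19.5 percentage points higher from compound 3 to compound 4 (beyond the scatter) at this aromatic carbon next to the ring nitrogen. Among the compounds shown here, this is the first change at this position, and it shows that the six-membered aromatic ring of carbon only in the leaving group is not required for this level of inhibition. No available evidence explains the increase.

From the compounds shown here alone, whether pyrrolidin-1-yl or morpholin-4-yl at this carbon would extend the increase remains open. Going by these compounds, it is also open whether piperidin-1-yl has the same effect with the ring pair of compound 2.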